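Replacing the amide ring of compound 1

A few compounds are considered here, and "the series" means these few. Any claim that something is new, unique, unknown or untested is made for them only; others in the source may bear on it.

Compound 1 `CCN(CC)S(=O)(=O)c1ccc(S(=O)(=O)N2CCC[C@@H](C(=O)N3CCS(=O)(=O)CC3)C2)cc1` was tested in a functional assay on BXPC-3 cells (Homo sapiens) for inhibition, read by MTT assay, with a stated time of 7 days (on this read-out lower numbers stand for stronger inhibition and higher numbers for weaker inhibition), and compound 1 gives 4430 nM. Among the three measured compounds this is the highest number, so the weakest inhibition. The nearest is compound 2 `O=C([C@@H]1CCCN(S(=O)(=O)c2ccc(S(=O)(=O)N3CC[C@@H](O)C3)cc2)C1)N1CCC(F)(F)CC1`, which in this assay gives 330 nM; the furthest is compound 3 `CCC(CC)S(=O)(=O)c1ccc(S(=O)(=O)N2CCC[C@@H](C(=O)N3CCC(F)(F)CC3)C2)cc1`, which gives 40 nM.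

Compound 4 `CCN(CC)S(=O)(=O)c1ccc(S(=O)(=O)N2CCC[C@@H](C(=O)N[C@H]3CC[C@@H](OC)CC3)C2)cc1` is compound 1 with one change: (4-methoxycyclohexyl)amino in place of 1,1-dioxothiomorpholin-4-yl on a carbonyl carbon. Going by the values given here, the only measured step, an 8.3-fold lower number from compound 2 to compound 3 (0.92 log units; beyond the scatter), concerns the group on a sulfonyl sulfur, at the opposite end of the shared core, and leaves the carbonyl carbon untouched. Among the compounds with values here, no measured pair changes the group on the carbonyl carbon, so the step from compound 1 to compound 4 has no direct precedent in these data, and the diethylamino sulfonyl end, common to compound 1 and compound 4, is the one that stands highest here.

Within the data shown here, with no guiding step, compound 4 is expected to stay close to compound 1, giving a step of a 1.3-fold lower number from compound 1 to compound 4 (0.10 log units; within the scatter) that is not expected to go beyond the scatter. The estimate for compound 4 is 3500 nM, within a range from 900 nM to 14000 nM.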

Compound 4, half-maximal inhibitory concentration: 2150 nM
For compound 4 the middle estimate is 1.6-fold (0.21 log units) above the measured one; measured number inside the range.
By their numbers in this assay, from the lowest: compound 3; then compound 2; then compound 4; then compound 1.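

Going by these compounds alone, this is the first measured change on the carbonyl carbon: in this assay, the swap gives a 2.1-fold lower number from compound 1 to compound 4 (0.31 log units; beyond the scatter), a modest step that lies beyond the scatter. With the diethylamino sulfonyl end held fixed, the group on the carbonyl carbon can therefore change from a ring holding a nitrogen and a sulfur to a carbon-only ring bearing a methoxy group, with only this small shift in the number. The change also alters several features at once, removing the two double bonds outside aromatic rings and adding a hydrogen-bond donor and two defined stereocentres, and nothing measured here explains the direction of the step.

With a single pair at this position, the effects of the amide hydrogen, the ring and the methoxy group cannot be separated, and the result cannot be assumed to hold for other groups at the sulfonyl end. A plain cyclohexylamino group or a morpholin-4-yl group on the same carbonyl carbon, each compared with compound 1, would help show which part of the change goes with the shift.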